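The source may hold more compounds than are shown below. What is called first, only, known or untested is meant among the compounds shown, and "the series" means these compounds.

Measured compounds in an assay on MDA-MB-231 cells for binding affinity to C-X-C chemokine receptor type 4 (Homo sapiens), read by immunofluorescence and microscopy, with stated times of 10 min and 30 min; a lower number here means that less compound is needed, a higher number that more compound is needed for the effect:

Compound 1 `Cc1ccc(S(=O)(=O)NCc2ccc(CNC(=O)c3ccc(Cl)cc3)cc2)cc1` gives 10 nM.
Compound 2 `Cc1ccc(S(=O)(=O)NCc2ccc(CNC(=O)c3cccc(Cl)c3)cc2)cc1` gives 100 nM.
Compound 3 `O=C(NCc1ccc(CNS(=O)(=O)c2ccccc2)cc1)c1cccc(Cl)c1` gives 1000 nM.

Compound 3 stands at the highest of the three numbers, with compound 2 nearest and compound 1 furthest away. The two steps on record, a 10-fold higher number from compound 1 to compound 2 (1.00 log units; beyond the scatter) and a 10-fold higher number from compound 2 to compound 3 (1.00 log units; beyond the scatter), each move the number up by the same size, yet neither touches a halogen on the carbonyl-bearing ring.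

Compound 4 `O=C(NCc1ccc(CNS(=O)(=O)c2ccccc2)cc1)c1cccc(F)c1` is the next member. The change from compound 3 is fluoro in place of chloro on an aromatic carbon: the (3-chlorophenyl)carbonyl becomes a (3-fluorophenyl)carbonyl. Among the compounds with values here, no measured pair shows this exchange, so the direction is open; a step of no more than the size seen, and likely toward a higher number, is expected, a 2.0-fold higher number from compound 3 to compound 4 (0.30 log units; within the scatter). Compound 4 is therefore estimated at 2000 nM, within 500 nM to 8000 nM.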

Compound 4, effective concentration (reported as EC, without a stated level of effect): 100 nM
Compound 4: middle estimate off by 20-fold (1.30 log units), on the high side; the whole stated range lies above it.
By their numbers in this assay, from the lowest: compound 1; then compounds 2 and 4 (each within the scatter of the next); then compound 3.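

In this assay, the step from chloro to fluoro is a 10-fold lower number from compound 3 to compound 4 (1.00 log units; beyond the scatter), so on this carbon, meta to a large group, the identity of the halogen changes the number, not only its place on the ring as in the earlier chloro pair. Among the steps on record, this is the only one that exchanges one halogen for another. No measurement on hand accounts for this result.

On these data alone, whether the exchange acts the same way in compound 1 or compound 2 remains open. So does how a methoxy group or an amine on this carbon would compare.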